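Series notes: from compound 3 toward compound 4

This account rests on a few compounds, and the source may have more. Where it says the series, first, only, none or still open, it means among the compounds named here.

Three compounds of the series have numbers in a functional assay on CHO-K1 cells for agonist activity at Glucose-dependent insulinotropic receptor (Homo sapiens), read by HTRF and cAMP accumulation, with a stated time of 30 min; on this read-out higher numbers stand for an effect only at larger amounts of compound and lower numbers for an effect already at smaller amounts. Compound 1 `CC(C)(C)OC(=O)N1CCC(CCCNc2ccc3c(c2)OCS3(=O)=O)CC1` gives 254 nM. Compound 2 `CC(C)(C)OC(=O)N1CCC(CCCNc2ccc3c(c2)C(=O)CO3)CC1` gives 88 nM. Compound 3 `CCc1cnc(N2CCC(CCCNc3ccc4c(c3)OCC4=O)CC2)nc1` gives 117 nM, the second highest of the three numbers; it sits nearest to compound 2, within the usual scatter, and furthest from compound 1, a gap that lies beyond the scatter. Within the data shown here, no pair among the three differs in a single place, so no step between measured compounds can be read from them.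

Compound 4 `CC(C)c1nsc(N2CCC(CCCNc3ccc4c(c3)OCC4=O)CC2)n1` is not yet measured. It differs from compound 3 by 3-isopropyl-1,2,4-thiadiazol-5-yl in place of 5-ethylpyrimidin-2-yl on an amine nitrogen in a ring. The shared core and the chain that links it to the ring amine are unchanged. Among the measured compounds shown here, with no comparable step among the measured compounds to lean on, the step from compound 3 to compound 4 is expected to be a 1.1-fold lower number from compound 3 to compound 4 (0.03 log units; within the scatter), not clearly beyond the scatter in either direction. Compound 4 is therefore expected to give 110 nM, within a range from 40 nM to 320 nM.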

Compound 4, half-maximal effective concentration: 121 nM
Compound 4: middle estimate off by 1.1-fold (0.04 log units), on the low side; measured number inside the range.
By their numbers in this assay, from the lowest: compounds 2, 3 and 4 (each within the scatter of the next); then compound 1.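

In this assay the series gains its first comparison in a single place, a 1.0-fold higher number from compound 3 to compound 4 (0.01 log units; within the scatter), so on an amine nitrogen in a ring 3-isopropyl-1,2,4-thiadiazol-5-yl and 5-ethylpyrimidin-2-yl cannot be told apart on this read-out. The change takes a six-membered aromatic ring to a five-membered one and brings in sulfur at an equal count of heavy atoms, and neither difference leaves a mark beyond the scatter. Nothing available bears on why the two groups read alike.

Steps from compound 1 or compound 2 to the others cannot be read, as those pairs differ in more than one place. From the compounds shown here alone, it remains open whether a much smaller group on this nitrogen, such as methyl, or a cyclopropyl in place of the isopropyl would read the same way.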